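A few compounds are considered here, and "the series" means these few. Any claim that something is new, unique, unknown or untested is made for them only; others in the source may bear on it.

Compound 1 `CCc1ccc(SCc2ccc(/C=C/C(=O)Nc3ccccc3N)cc2)cc1`: 1300 nM
Compound 2 `COc1ccc(SCc2ccc(C(=O)Nc3ccccc3N)cc2)cc1`: 2570 nM

Within the data shown here, only two numbers are available so far, both from a functional assay on A549 cells (Homo sapiens) for antiproliferative activity, read by CCK-8 assay, with a stated time of 72 h; on this read-out lower numbers stand for stronger inhibition and higher numbers for weaker inhibition. Compound 1 gives 1300 nM and compound 2 gives 2570 nM. Among the measured compounds shown here, these values lie within the usual scatter of each other, so the two compounds cannot be told apart, and compound 1 stands level with the only other measured compound.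

Compound 3 `Nc1ccccc1NC(=O)/C=C/c1ccc(CSc2cccc3ccccc23)cc1` keeps the core of compound 1 and changes one group: naphthalen-1-yl in place of 4-ethylphenyl on a sulfur, (naphthalen-1-yl in place of 4-ethylphenyl on a sulfur). Both groups contain only carbon and carry no net charge. For the measured compounds named here, no measured pair of compounds shows what a change at this place does in this assay, so there is no direct guide to its size. The expectation therefore starts from compound 1 at 1300 nM, and only a modest shift towards stronger inhibition is anticipated, possibly none beyond the scatter. The expected change is a 1.3-fold lower number from compound 1 to compound 3 (0.11 log units; within the scatter). For compound 3 the estimated value is 1000 nM, with an expected range from 350 nM to 3000 nM.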

Compound 3, half-maximal inhibitory concentration: 830 nM
Compound 3: middle estimate off by 1.2-fold (0.08 log units), on the high side; measured number inside the range.
By their numbers in this assay, from the lowest: compounds 3, 1 and 2 (each within the scatter of the next, the first and the last beyond it).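

In this assay, among these compounds, placing naphthalen-1-yl in place of 4-ethylphenyl on a sulfur gives a 1.6-fold lower number from compound 1 to compound 3 (0.19 log units; within the scatter), which is the first direct reading of what a change at this place does, and the two compounds cannot be told apart. The swap is not a small one on paper, since the entering group has 10 heavy atoms and 2 six-membered aromatic rings, while the leaving group has 8 heavy atoms and one such ring, yet the read-out stays level within the usual scatter, so at least this one exchange of carbon-only groups is tolerated on the sulfur. No measurement on hand accounts for this result.

Both groups are made of carbon only and carry no net charge, so the compounds shown leave open how this place responds to a group of a different kind, such as an amine, a carboxylic acid or a longer saturated chain. Also open, going by these compounds, is whether naphthalen-1-yl would read the same way on the core of compound 2, since this single step comes from the core of compound 1 alone.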